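The source may report more compounds than this note shows. Statements on the series, on what has been measured and on what is new or still open speak of the compounds shown alone.

Measured so far:
- compound 1 `COc1ccc(C(=O)c2cc(OC)c(OC)c(OC)c2)cc1NC(=O)/C=C/c1ccc(F)cc1`: 300 nM
- compound 2 `COc1ccc(/C=C/C(=O)Nc2cc(C(=O)c3cc(OC)c(OC)c(OC)c3)cc(OC)c2OC)cc1N`: 13900 nM

Among the compounds with values here, in a functional assay on ME-180 cells (Homo sapiens) for cytotoxicity, read by MTT assay, with a stated time of 72 h (a lower number here means a stronger inhibitor, a higher number a weaker inhibitor), compound 2 gives 13900 nM, the highest of the two numbers; the only neighbour, compound 1, gives 300 nM, a gap beyond the scatter. Within the data shown here, the two compounds differ in more than one place, so no single step is recorded between them; their values show only that the pair sits far apart.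

Compound 3 `COc1cc(C(=O)c2cc(OC)c(OC)c(OC)c2)cc(NC(=O)/C=C/c2ccc(F)cc2)c1OC` is not yet measured in this assay. It keeps the core of compound 2 and differs from it in one place: 4-fluorophenyl in place of 3-amino-4-methoxyphenyl on a double-bonded chain carbon bound to a double-bonded chain carbon. Among the measured compounds shown here, the aryl group that enters is the one carried by compound 1, whose number in this assay is 300 nM, while compound 3 keeps the core of compound 2.

Given that, a large step downward is expected, though the core of compound 3 is not that of compound 1 and no step isolating the aryl change is available. The step from compound 2 to compound 3 in this assay is estimated at a 23-fold lower number from compound 2 to compound 3 (1.36 log units; beyond the scatter). Compound 3 is expected to give about 600 nM, with a range of 150 nM to 2500 nM.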

Compound 3, half-maximal inhibitory concentration: 1000 nM
Estimate against measurement, compound 3: 1.7-fold (0.22 log units) below; the range from low to high includes it.
By their numbers in this assay, from the lowest: compound 1; then compound 3; then compound 2.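

In this assay, the aryl group on a double-bonded chain carbon bound to a double-bonded chain carbon now has a direct reading with the rest of the structure held fixed: 4-fluorophenyl in place of 3-amino-4-methoxyphenyl gives a 14-fold lower number from compound 2 to compound 3 (1.14 log units; beyond the scatter) and is classed as a large step. The same compound also isolates the methoxy in place of hydrogen on an aromatic carbon, which gives a 3.3-fold higher number from compound 1 to compound 3 (0.52 log units; beyond the scatter) and is classed as modest, so this methoxy is not neutral with the 4-fluorophenyl group in place. Compound 3 therefore links compound 1 and compound 2 through two single changes, and the aryl change is the larger of the two in this small set.

As far as these compounds go, it remains open whether the higher number of compound 2 goes with the amine or the methoxy of 3-amino-4-methoxyphenyl, and whether the fluorine itself matters, which a plain phenyl or a chlorophenyl on the same chain carbon would test. Nothing measured here speaks to the reason for either step.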